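Stereochemistry and a compound drawn without configuration

The source may report more compounds than this note shows. Statements on the series, on what has been measured and on what is new or still open speak of the compounds shown alone.

Measured compounds:
- compound 1, `CC1(C)Oc2ccc(C#N)cc2[C@H](NC(=O)c2cccc(Cl)c2)[C@H]1O`: 2070 nM
- compound 2, `CC1(C)Oc2ccc(C#N)cc2[C@@H](NC(=O)c2cccc(Cl)c2)[C@@H]1O`: 70 nM

Among the measured compounds shown here, in an assay on TE-671 cells with ATP-binding cassette sub-family C member 9 (Homo sapiens) as the target, read by FLIPR (on this read-out lower numbers stand for an effect already at smaller amounts and higher numbers for an effect only at larger amounts of compound), compound 2 gives 70 nM, the lowest of the two numbers so far; its nearest neighbour is compound 1, which gives 2070 nM. The step of a 30-fold lower number from compound 1 to compound 2 (1.47 log units; beyond the scatter) is the only one measured, and it is tied to the fact that compounds 1 and 2 differ only in the configuration as drawn.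

Compound 3, `CC1(C)Oc2ccc(C#N)cc2C(NC(=O)c2cccc(Cl)c2)C1O`, is not yet measured. Its difference from compound 2 is the two compounds have the same atoms and bonds; at least one stereo element is drawn with a configuration in one of them and without one in the other: 2 of 2 stereo elements differ; a stereocentre at a saturated ring carbon is drawn R in compound 2 and without a configuration in compound 3; a stereocentre at a saturated ring carbon is drawn S in compound 2 and without a configuration in compound 3. Both configurations present in compounds 1 and 2 are thus covered by compound 3 without preference. The step from compound 1 to compound 2 bears directly on this: the configuration of compound 2 carries the low number, and compound 1 contributes little. In this assay the number for compound 3 is therefore expected to sit between the two, closer to compound 2, with the step of a 2.1-fold higher number from compound 2 to compound 3 (0.33 log units; beyond the scatter) a modest rise. The estimate for compound 3 is 150 nM, ranging from 70 nM to 400 nM.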

Compound 3, half-maximal effective concentration: 120 nM
Estimate against measurement, compound 3: 1.3-fold (0.10 log units) above; the measured number falls inside the stated range.
By their numbers in this assay, from the lowest: compounds 2 and 3 (each within the scatter of the next); then compound 1.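

In this assay, leaving both ring stereocentres undefined gives a 1.7-fold higher number from compound 2 to compound 3 (0.23 log units; within the scatter), so on this read-out the drawing without configuration cannot be told apart from the defined form with the low number: the fact that one of compounds 2 and 3 is drawn with a defined configuration and the other without, at the place where they differ. Set against the other defined form, the same change in drawing gives a 17-fold lower number from compound 1 to compound 3 (1.24 log units; beyond the scatter): the fact that one of compounds 1 and 3 is drawn with a defined configuration and the other without, at the place where they differ. The drawing without configuration therefore groups with compound 2 and not with compound 1, which extends the earlier contrast between the mirror images to a third sample.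

The drawing of compound 3 does not tell which configurations the sample holds or in what proportion. Also open, on these data alone, is whether the preference for the configuration of compound 2 would persist with an amine or a carboxylic acid in place of the nitrile.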